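Inhibition notes: compound 3 to compound 4

The compounds below may be only part of what the source reports. "The series", "measured", "known", "first", "only" and "open" are said of these compounds alone.

The series shares one core, seen in compound 1 `CN(C(=O)NC(=O)c1ccc([N+](=O)[O-])cc1)c1nc(C(F)(F)F)c(C(=O)N/N=C/c2cccc(C(F)(F)F)c2)s1`, compound 2 `CN(C(=O)NC(=O)c1ccc(F)c(F)c1)c1nc(C(F)(F)F)c(C(=O)N/N=C/c2cccc(C(F)(F)F)c2)s1` and compound 3 `CN(C(=O)NC(=O)c1c(F)cccc1F)c1nc(C(F)(F)F)c(C(=O)N/N=C/c2cccc(C(F)(F)F)c2)s1`, and differs only in the aromatic group on the imide-side carbonyl. The read-out is an ADME assay on L02 cells (Homo sapiens) for inhibition, read by MTT assay, with a stated time of 72 h; a lower number here means a stronger inhibitor, a higher number a weaker inhibitor. In this assay, among the measured compounds shown here, compound 2 gives 23.5 ug/mL, the only number so far. For compound 1 the entry is "not determined" (no result reported), and for compound 3 the entry is "not determined" (no result reported), so compound 3 stands without a number of its own, and nothing in the measured set lets one say how it compares with compound 2.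

Compound 4 `CN(C(=O)NC(=O)c1ccc(C(F)(F)F)cc1)c1nc(C(F)(F)F)c(C(=O)N/N=C/c2cccc(C(F)(F)F)c2)s1` is the next entry. Its change from compound 3 is 4-(trifluoromethyl)phenyl in place of 2,6-difluorophenyl on a carbonyl carbon. For the measured compounds named here, no step between measured compounds is known, so the size of this step in this assay cannot be read from the data; the one number at hand, from compound 2, is taken as the anchor for the whole set, and the step from compound 3 to compound 4 is expected to stay within the scatter rather than move in a clear direction.

Compound 4 is therefore estimated at 25 ug/mL in this assay, with a range from 10 ug/mL to 60 ug/mL.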

Compound 4, half-maximal inhibitory concentration: 18 ug/mL
Compound 4: the middle estimate sits 1.4-fold (0.14 log units) above what was measured, and the stated range covers the measured number.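

In this assay, this position on the carbonyl carbon now has a first readable step: replacing 3,4-difluorophenyl with 4-(trifluoromethyl)phenyl gives a 1.3-fold lower number from compound 2 to compound 4 (0.12 log units; within the scatter), so the two groups cannot be told apart in this read-out. With compound 2 at 23.5 ug/mL and compound 4 at 18 ug/mL, the set holds two numbers instead of one, though neither step involving a compound without a number, including the change from 2,6-difluorophenyl to 4-(trifluoromethyl)phenyl, can be read. No measurement at hand bears on why this change leaves the number within the scatter.

As far as these compounds go, the two numbers cover only fluorine-bearing phenyl groups at this place, so it remains open whether any group on this carbonyl carbon can move the number in this assay beyond the scatter. A phenyl group carrying an amine or a carboxylic acid, or a longer alkyl chain in place of the phenyl ring, would test this with a group of a different kind from those compared here.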